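The source may hold more compounds than are shown below. What is called first, only, known or untested is meant among the compounds shown, and "the series" means these compounds.

Measured compounds in an assay on isolated protein for inhibition of NEDD8-activating enzyme E1 regulatory subunit (Homo sapiens), read by Western blot, with stated times of 10 min and 30 min, tested at 25 uM; a higher number here means more inhibition at the concentration tested (going by the name of the read-out), a lower number less inhibition:
- compound 1, `CCCNC(=O)c1cccc2nc(OCC)n(Cc3ccc(-c4ccccc4-c4nnn[nH]4)cc3)c12`, gives 32.6%
- compound 2, `CCOc1nc2cccc(C(=O)Nc3ccccc3)c2n1Cc1ccc(-c2ccccc2-c2nnn[nH]2)cc1`, gives 34.6%
- compound 3, `CCOc1nc2cccc(C(=O)NCc3ccccc3)c2n1Cc1ccc(-c2ccccc2-c2nnn[nH]2)cc1`, gives 48.9%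

Compound 3 stands highest of the three numbers. Its lead over compound 2 is a number 14.3 percentage points higher from compound 2 to compound 3 (beyond the scatter), and over compound 1 it is a number 16.3 percentage points higher from compound 1 to compound 3 (beyond the scatter), both beyond the usual scatter, whereas compound 1 and compound 2 sit together within it, a number 2 percentage points higher from compound 1 to compound 2 (within the scatter).

Compound 4, `CCOc1nc2cccc(C(=O)NCc3ccc(F)cc3)c2n1Cc1ccc(-c2ccccc2-c2nnn[nH]2)cc1`, differs from compound 3 in one place: fluoro in place of hydrogen on an aromatic carbon. The measured steps all swap the whole group on the amide-type nitrogen, from propyl to phenyl or benzyl, and the largest of them were only modest. None of them changes a single substituent on the benzyl ring, so they bear on this step only loosely, and they give no hint of a change as large as theirs. The expectation for compound 4 is therefore a step of about a number 1.1 percentage points higher from compound 3 to compound 4 (within the scatter), not beyond the scatter. Compound 4 is estimated at 50%, with a range from 35% to 65%.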

Compound 4, a percentage reported as inhibition, at one concentration (the size of the read-out at that concentration, not a potency): 38.1%
Estimate against measurement, compound 4: 11.9 percentage points above; measured number inside the range.
By their numbers in this assay, from the lowest: compounds 1, 2 and 4 (each within the scatter of the next); then compound 3.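

In this assay, the carbon of the benzyl ring that carries the new group proves sensitive to a change of a single heavy atom: fluoro in place of hydrogen costs inhibition (a number 10.8 percentage points lower from compound 3 to compound 4 (beyond the scatter)). This small change also removes the lead that the benzyl amide held over the other two amides, as the 4-fluorobenzyl amide sits within the scatter of both the phenyl amide (a number 3.5 percentage points higher from compound 2 to compound 4 (within the scatter)) and the propyl amide (a number 5.5 percentage points higher from compound 1 to compound 4 (within the scatter)). Nothing measured here explains why one atom at this position has this effect.

With fluoro as the only substituent shown on this ring, it remains open whether the drop is particular to fluoro or follows any group on that carbon. A chloro, methyl or methoxy group at the same carbon would help separate the two.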